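A few compounds are considered here, and "the series" means these few. Any claim that something is new, unique, unknown or untested is made for them only; others in the source may bear on it.

Working notes on the series in a functional assay on MGC-803 cells (Homo sapiens) for inhibition, read by MTT assay, with a stated time of 48 h; a lower number here means a stronger inhibitor, a higher number a weaker inhibitor.

Compound 1 `COC(=O)c1cc(CNc2cc(OC)c(OC)c(OC)c2)ccc1OC` gives 49600 nM, the highest of the three numbers measured. Among the compounds with values here, compound 2 `COc1ccc(CN(C(=O)CN=[N+]=[N-])c2cc(OC)c(OC)c(OC)c2)cc1O` gives 120 nM, and compound 3 `COc1ccc(CN(C(=O)/C=C/CBr)c2cc(OC)c(OC)c(OC)c2)cc1O` gives 71 nM; both sit far below compound 1, beyond the scatter, and the one step measured within a single change, a 1.7-fold lower number from compound 2 to compound 3 (0.23 log units; within the scatter), stays within the scatter. Compounds 2 and 3 differ from compound 1 in more than one place, so their gap to compound 1 cannot be assigned to any single change.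

Compound 4 `COc1ccc(CNc2cc(OC)c(OC)c(OC)c2)cc1N` is not yet measured. It differs from compound 1 by amino in place of methoxycarbonyl on an aromatic carbon, the amino group sitting ortho to a methoxy group and meta to a large group on the shared core. Within the data shown here, no measured step in this assay covers this change: the step from compound 2 to compound 3 concerns the group on the carbonyl carbon only, and the gap from compound 1 to compounds 2 and 3 carries several changes at once. With nothing to anchor a direction, the expected step of a 2.0-fold lower number from compound 1 to compound 4 (0.30 log units; within the scatter) is small and uncertain, with wide limits on either side. The estimate for compound 4 in this assay is 25000 nM, expected between 4000 nM and 100000 nM.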

Compound 4, half-maximal inhibitory concentration: 7970 nM
Compound 4: middle estimate off by 3.1-fold (0.50 log units), on the high side; low and high end bracket the measured number.
By their numbers in this assay, from the lowest: compounds 3 and 2 (each within the scatter of the next); then compound 4; then compound 1.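

In this assay, within the data shown here, this is the first single change read at this aromatic carbon, ortho to a methoxy group and meta to a large group: amino in place of methoxycarbonyl gives a 6.2-fold lower number from compound 1 to compound 4 (0.79 log units; beyond the scatter), a modest step beyond the scatter. On this core, the position therefore responds to the group it carries, and the methoxycarbonyl is not needed to keep a measurable number, since the smaller amino, with one heavy atom against four and one hydrogen-bond donor against none, gives the lower number. No measured property or other evidence bears on the origin of this step, so the size of the group, its donor count and its identity cannot be separated.

This single pair cannot show whether the step comes from gaining the amino or from losing the methoxycarbonyl, and a carboxylic acid, a methylamino group or an acetamide on the same carbon would help to separate the two. From the compounds shown here alone, compounds 2 and 3 differ from compound 4 in more than one place, so the share of their lower numbers that belongs to this position also remains open.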